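From chloro to dimethylamino at the limit

This account rests on a few compounds, and the source may have more. Where it says the series, first, only, none or still open, it means among the compounds named here.

In an ADME assay on Raji cells (Homo sapiens) for cytotoxicity, read by luminescence, with a stated time of 72 h (a lower number here means that less compound is needed, a higher number that more compound is needed for the effect), the three measured compounds read as follows:
compound 1 `CCOC(=O)c1c(-c2cccc(OC)c2)[nH]c2cc(OC)ccc2c1=O` gives > 21500 nM
compound 2 `CCOC(=O)c1c(-c2cccc(F)c2)[nH]c2cc(OC)ccc2c1=O` gives > 21500 nM
compound 3 `CCOC(=O)c1c(-c2cccc(Cl)c2)[nH]c2cc(OC)ccc2c1=O` gives > 21500 nM

Each of these readings is a limit of the assay and not a number. Compound 3 stands with > 21500 nM as such a limit. All three compounds share the limit of > 21500 nM in this assay, at which 3 of the 3 values shown sit, and none of them gives a readable number.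

Compound 4 `CCOC(=O)c1c(-c2cccc(N(C)C)c2)[nH]c2cc(OC)ccc2c1=O` differs from compound 3 in one place, dimethylamino in place of chloro on an aromatic carbon with dimethylamino in place of chloro on an aromatic carbon. Here a step that the two limits leave unreadable from compound 1 to compound 2, a step that the two limits leave unreadable from compound 1 to compound 3 and a step that the two limits leave unreadable from compound 2 to compound 3 are the steps that bear on it, and none has a size that can be read. For the measured compounds named here, compound 3 with > 21500 nM offers no number to start from, so no step of readable size or direction is expected in this assay, and another limit is the likeliest result. The estimate means an expected a number no higher from compound 3 to compound 4 (the limit leaves the size open) of no readable size. For compound 4 the estimated value is 21500 nM with an expected range of 8000 nM to 30000 nM in this reading.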

Compound 4, half-maximal effective concentration: > 21500 nM
Compound 4 gave a limit, no number (the forecaster's own chance of this, stated with the estimate: 80%); the middle value lies on the limit itself.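

In this assay compound 4 gives > 21500 nM, a limit of the assay and not a number, so no step from compound 1, compound 2 or compound 3 to compound 4 can be read: the limit of > 21500 nM in this assay, at which 4 of the 4 values shown sit.

The compounds shown leave open how these four compare, and whether any change to the shared core would give a readable number.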